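This account rests on a few compounds, and the source may have more. Where it says the series, first, only, none or still open, it means among the compounds named here.

Series notes. Compound 1 `COc1ccc(-c2cc(C(=O)/C=C/c3ccccc3)nc3cc(-c4ccccc4)nn23)cc1OC` in an ADME assay on HEK293 cells (Homo sapiens) for antiproliferative activity, read by MTT assay, with a stated time of 24 h (on this read-out lower numbers stand for stronger inhibition and higher numbers for weaker inhibition), gives 64100 nM; compound 2 `COc1ccc(-c2cc(C(=O)/C=C/c3ccc(C)cc3)nc3cc(-c4ccccc4)nn23)cc1OC` gives 57400 nM; compound 3 `COc1cc(-c2cc(C(=O)/C=C/c3ccccc3)nc3cc(-c4ccccc4)nn23)cc(OC)c1OC` gives 44800 nM. The two steps among them, a 1.1-fold lower number from compound 1 to compound 2 (0.05 log units; within the scatter) and a 1.4-fold lower number from compound 1 to compound 3 (0.16 log units; within the scatter), both fall within the scatter, so compound 3 is not set apart from either companion. Compound 4 `COc1ccc(/C=C/C(=O)c2cc(-c3cc(OC)c(OC)c(OC)c3)n3nc(-c4ccccc4)cc3n2)cc1` differs from compound 3 by methoxy in place of hydrogen on an aromatic carbon. For the measured compounds named here, the only step of the same kind, a 1.4-fold lower number from compound 1 to compound 3 (0.16 log units; within the scatter), also placed a methoxy onto an aromatic carbon and stayed within the scatter, so in this assay no shift beyond the scatter is expected for compound 4 in either direction, the expected step being a 1.1-fold lower number from compound 3 to compound 4 (0.05 log units; within the scatter). Compound 4 is accordingly estimated at 40000 nM, with a range from 18000 nM to 90000 nM.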

Compound 4, half-maximal inhibitory concentration: 46600 nM
For compound 4 the middle estimate is 1.2-fold (0.07 log units) below the measured one; the range from low to high includes it.
By their numbers in this assay, from the lowest: compounds 3, 4, 2 and 1 (each within the scatter of the next).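

In this assay the change from 2-phenylethenyl to 2-(4-methoxyphenyl)ethenyl gives a 1.0-fold higher number from compound 3 to compound 4 (0.02 log units; within the scatter) and so stays within the scatter. Methyl on this same phenyl ring gave a 1.1-fold lower number from compound 1 to compound 2 (0.05 log units; within the scatter) on the core of compound 1, so two different groups at this place, on two different companions, have now left the number within the scatter. The methoxy step on the other aryl ring is matched here, with no sign yet that either ring responds.

Going by these compounds, whether an amine or a carboxylic acid at this place would move the number beyond the scatter remains open. No measurement here bears on why these steps stay so small.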